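A few compounds are considered here, and "the series" means these few. Any claim that something is new, unique, unknown or untested is made for them only; others in the source may bear on it.

Series notes. Compound 1 `COC1=C[C@H](O)[C@H](C/C=C(\C)CC/C=C(\C)C[C@@H]2C[C@@H](C)C(=O)O2)[C@@H](C)C1=O` sits at the floor of a functional assay on PC-3 cells (Homo sapiens) for inhibition, read by sulforhodamine B assay, with a stated time of 48 h; a lower number here means a stronger inhibitor of growth, a higher number a weaker inhibitor of growth: in this assay compound 1 gives > 30000 nM, a limit rather than a number. Compound 2 `COC1=C(OC)[C@H](O)[C@H](C/C=C(\C)CC/C=C(\C)C[C@@H]2C[C@@H](C)C(=O)O2)[C@@H](C)C1=O` carries a methoxy in place of hydrogen on a double-bonded ring carbon; in this assay compound 2 likewise gives > 30000 nM, again a limit. Compound 3 `COC1=C(OC)[C@H](OC(C)=O)[C@H](C/C=C(\C)CC/C=C(\C)C[C@@H]2C[C@@H](C)C(=O)O2)[C@@H](C)C1=O` has acetyl in place of hydrogen on an oxygen on a saturated carbon, and in this assay compound 3 also gives only the limit > 30000 nM. The step that the two limits leave unreadable from compound 1 to compound 2 and the step that the two limits leave unreadable from compound 2 to compound 3 are both unreadable, since every value rests at the limit of > 30000 nM in this assay, at which 3 of the 3 values shown sit. Compound 2 therefore stands only as a limit among limits, with no number of its own. Compound 4 `COC1=C(OC)[C@H](O)[C@H](C/C=C(\C)CC/C=C(\C)CC/C=C(\C)CO)[C@@H](C)C1=O` differs from compound 2 by a group of 6 heavy atoms (5 carbon, 1 oxygen; no ring) in place of a group of 7 heavy atoms (5 carbon, 2 oxygen; one five-membered non-aromatic ring with 1 hetero atom), on a saturated chain carbon bound to a double-bonded chain carbon. Among the measured compounds shown here, no measured step touches that change, and the two unreadable steps give no direction. Compound 4 is expected to stay at the limit, with an expected step that the limit leaves unreadable from compound 2 to compound 4. The estimate for compound 4 in this assay is 40000 nM, with an expected range from 10000 nM to 150000 nM.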

Compound 4, concentration for 50% growth inhibition: > 30000 nM
Compound 4: a limit, no number; the forecaster's own chance of this, stated with the estimate: 80%; the middle value does not contradict the limit.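

In this assay, among the compounds shown here, compound 4 gives > 30000 nM as a limit and not a number, so no step from compound 2 to compound 4 can be read, since both rest at the same limit: the limit of > 30000 nM in this assay, at which 4 of the 4 values shown sit. The compounds shown leave open whether any of these changes alters growth inhibition at all, and in which direction.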